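The source may hold more compounds than are shown below. What is called first, only, known or untested is meant among the compounds shown, and "the series" means these compounds.

Compound 1 `CC(=O)Nc1ccc(S(=O)(=O)NNC(=O)c2cccnc2Nc2ccc(Cl)cc2)cc1` and compound 2 `O=C(NNS(=O)(=O)c1ccc(F)cc1)c1cccnc1Nc1ccc(Cl)cc1Cl` share one core and were both tested in a functional assay on HOP-62 cells (Homo sapiens) for antiproliferative activity; on this read-out higher numbers stand for lower toxicity in this test and lower numbers for higher toxicity in this test. For compound 1 only a limit of the assay is reported, > 100000 nM. For compound 2 likewise only a limit is reported, > 100000 nM. Among the compounds with values here, compound 1 therefore stands at the limit of > 100000 nM in this assay, at which 2 of the 2 values shown sit, and no step between measured compounds exists to judge from. Compound 3 `O=C(NNS(=O)(=O)c1ccc(Cl)cc1Cl)c1cccnc1Nc1ccc(Cl)cc1` differs from compound 1 by 2,4-dichlorophenyl in place of 4-acetamidophenyl on a sulfonyl sulfur. The step of a number no higher from compound 1 to compound 3 (the limit leaves the size open) is expected to stay within the scatter. Compound 3 is accordingly estimated at 100000 nM, in the range 30000 nM to 300000 nM, most likely reported again only as a limit.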

Compound 3, concentration lethal to 50% of the cells: 85100 nM
Compound 3: the middle estimate sits 1.2-fold (0.07 log units) above what was measured; the range from low to high includes it.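

In this assay, 2,4-dichlorophenyl in place of 4-acetamidophenyl on a sulfonyl sulfur gives an at least 1.1-fold lower number from compound 1 to compound 3 (0.07 log units; that floor lies within the scatter). As far as these compounds go, compound 3 alone carries a number rather than a limit, so this position can yield a measurable read-out, but the step is only a floor and its true size stays unknown. The shown set remains dominated by a limit: the limit of > 100000 nM in this assay, at which 2 of the 3 values shown sit.

From the compounds shown here alone, whether an amine or a carboxylic acid in place of 2,4-dichlorophenyl on a sulfonyl sulfur would give a step beyond the scatter stays open.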